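This account rests on a few compounds, and the source may have more. Where it says the series, first, only, none or still open, it means among the compounds named here.

Measured so far:
Compound 1 `C[C@H]1Cn2ncc(N3CC(c4ccccc4)CC3=O)c2CN1S(=O)(=O)Nc1cc(F)c(F)c(F)c1`: > 2000 nM (a limit)
Compound 2 `O=C1CC(c2cnc(C(F)(F)F)s2)CN1c1cnn2c1CN(C(=O)Nc1cc(F)c(F)c(F)c1)C(C1CC1)C2`: 38500 nM
Compound 3 `O=C1c2ccccc2CN1c1cnn2c1CN(C(=O)Nc1cc(F)c(F)c(F)c1)C(C1CC1)C2`: 38500 nM

In a toxicity assay on HepG2 2.2.15 cells (Homo sapiens) for cytotoxicity, read by CellTiter-Glo (on this read-out higher numbers stand for lower toxicity in this test and lower numbers for higher toxicity in this test), compound 1 gives only a limit, > 2000 nM. In this assay compound 2 gives 38500 nM, level with compound 3 at 38500 nM.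

Compound 4 `O=C1CC(c2ccc(F)cn2)CN1c1cnn2c1CN(C(=O)Nc1cc(F)c(F)c(F)c1)C(C1CC1)C2` has not yet been measured. It carries 5-fluoropyridin-2-yl in place of 2-(trifluoromethyl)-1,3-thiazol-5-yl on a saturated ring carbon. Going by the values given here, no step between measured compounds covers this change, so no shift beyond the scatter is expected, in either direction, from the level of compound 2 at 38500 nM. The expected 1.1-fold lower number from compound 2 to compound 4 (0.04 log units; within the scatter) is small. Compound 4 is estimated at 35000 nM, with an expected range of 15000 nM to 60000 nM.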

Compound 4, half-maximal cytotoxic concentration: 38500 nM
Compound 4: the middle estimate sits 1.1-fold (0.04 log units) below what was measured, and the stated range covers the measured number.
By their numbers in this assay, from the lowest: compounds 2, 3 and 4 (each within the scatter of the next).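

In this assay, 5-fluoropyridin-2-yl in place of 2-(trifluoromethyl)-1,3-thiazol-5-yl on the saturated ring carbon gives no change at the digits printed from compound 2 to compound 4 (within the scatter). Going by these compounds alone, this is the first step read at this position, and it shows that the number holds when a five-membered aromatic ring with its trifluoromethyl gives way to a six-membered aromatic ring with a fluorine. Nothing measured here accounts for this sameness.

On these data alone, whether an amine or a carboxylic acid on this carbon would move the number stays open. Compound 1 gives only a limit, > 2000 nM, and stays outside any comparison.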